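The compounds below may be only part of what the source reports. "The series", "measured", "known", "first", "only" and "open" are said of these compounds alone.

Working notes on the series.

Compound 3 `COc1cc(C2=NN(C(C)=O)C(c3ccccc3F)O2)cc(OC)c1OC` gives 29.6% in a functional assay on BGC-823 cells (Homo sapiens) for antiproliferative activity, read by MTT assay, tested at 1 uM; on this read-out lower numbers stand for a weaker effect and higher numbers for a stronger effect at the one concentration tested. Within the data shown here, of the three numbers measured so far it is the second highest: compound 1 `COc1cc(C2=NN(C(C)=O)C(c3ccccc3C(F)(F)F)O2)cc(OC)c1OC` gives 31.8%, and a number 2.2 percentage points lower from compound 1 to compound 3 (within the scatter), so the two lie within the scatter of each other; compound 2 `COc1cc(C2=NN(C(C)=O)C(c3ccc(Cl)c(Cl)c3)O2)cc(OC)c1OC` gives -0.8%, and a number 30.4 percentage points higher from compound 2 to compound 3 (beyond the scatter).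

The next compound, compound 4 `COc1cc(C2=NN(C(C)=O)C(c3ccc(Cl)c([N+](=O)[O-])c3)O2)cc(OC)c1OC`, differs from compound 3 in one place: 4-chloro-3-nitrophenyl in place of 2-fluorophenyl on a saturated ring carbon.

Among the measured compounds shown here, two measured steps bear on this change. Both concern the group on the same saturated ring carbon. a number 32.6 percentage points lower from compound 1 to compound 2 (beyond the scatter). a number 30.4 percentage points higher from compound 2 to compound 3 (beyond the scatter). In both, the 3,4-dichlorophenyl compound sits far below the compounds that carry a single substituent on that phenyl. For the measured compounds named here, the 4-chloro-3-nitrophenyl group of compound 4 again places two substituents in the 3- and 4-positions of that phenyl, so a large downward step is expected, though the nitro group itself has no measured counterpart here and the range is kept wide.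

For compound 4 the expected value in this assay is 8%, with a range from -8% to 26%, which is an expected step of a number 21.6 percentage points lower from compound 3 to compound 4 (beyond the scatter).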

Compound 4, a percentage reported as inhibition, at one concentration (the size of the read-out at that concentration, not a potency): -2.3%
Compound 4: the middle estimate sits 10.3 percentage points above what was measured, and the stated range covers the measured number.
By their numbers in this assay, from the lowest: compounds 4 and 2 (each within the scatter of the next); then compounds 3 and 1 (each within the scatter of the next).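

In this assay, the low number of the 3,4-dichlorophenyl compound is no longer unique to that group: with nitro in place of chloro on the aromatic carbon, the two compounds cannot be told apart (a number 1.5 percentage points lower from compound 2 to compound 4 (within the scatter)). The 4-chloro-3-nitrophenyl group also sits far below both phenyl groups with a single substituent (a number 31.9 percentage points lower from compound 3 to compound 4 (beyond the scatter); a number 34.1 percentage points lower from compound 1 to compound 4 (beyond the scatter)), so across these four compounds the two disubstituted phenyl groups fall together, with none going against this. No supporting measurement bears on why this position behaves this way.

The single-substituent groups shown are 2-fluorophenyl and 2-(trifluoromethyl)phenyl, so the number of substituents cannot be separated from where they sit on the phenyl. As far as these compounds go, whether a lone chloro or nitro at the 3- or 4-position, or an amine or carboxylic acid there, would group with compounds 1 and 3 or with compounds 2 and 4 remains open.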